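Bromo in Place of Amino on the Phenoxy Arm

The source may hold more compounds than are shown below. What is called first, only, known or untested is meant among the compounds shown, and "the series" means these compounds.

Compound 2 `Nc1ccc(OCc2cn(-c3cc(=O)oc4ccc(Br)cc34)nn2)cc1` gives 2090 nM in a functional assay on SW480 cells (Homo sapiens) for antiproliferative activity, read by MTT assay, with a stated time of 48 h (on this read-out higher numbers stand for weaker inhibition and lower numbers for stronger inhibition), the lowest of the two numbers recorded so far. Compound 1 `O=c1cc(-n2cc(COc3cccnc3)nn2)c2cc(Br)ccc2o1` gives 39800 nM in this assay. Within the data shown here, the only measured step, a 19-fold lower number from compound 1 to compound 2 (1.28 log units; beyond the scatter), shows that the aryl group on the ether oxygen can move the read-out a long way. Compound 3 `O=c1cc(-n2cc(COc3ccc(Br)cc3)nn2)c2cc(Br)ccc2o1` carries bromo in place of amino on an aromatic carbon. Among the measured compounds shown here, no measured pair shares exactly this change; the single step available concerns a different aryl exchange and speaks only to the sensitivity of this position. For the measured compounds named here, with that step as the sole guide, a loss of part of the gain seen for compound 2 is expected, though the size is uncertain. Compound 3 is estimated at 8000 nM, within 2000 nM to 30000 nM, an expected step of a 3.8-fold higher number from compound 2 to compound 3 (0.58 log units; beyond the scatter).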

Compound 3, half-maximal inhibitory concentration: 1310 nM
Compound 3: middle estimate off by 6.1-fold (0.79 log units), on the high side, outside the stated range (below it).
By their numbers in this assay, from the lowest: compounds 3 and 2 (each within the scatter of the next); then compound 1.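

The change from amino to bromo gives a 1.6-fold lower number from compound 2 to compound 3 (0.20 log units; within the scatter), so in this assay compound 2 and compound 3 cannot be told apart, and the read-out at this position does not depend on keeping the amino group with its hydrogen-bond donor. The exchange of the pyridin-3-yl group gives a 30-fold lower number from compound 1 to compound 3 (1.48 log units; beyond the scatter), a large step like the one to compound 2, so among these three compounds the large gain over compound 1 is not tied to the amino group and is seen with both 4-aminophenyl and 4-bromophenyl. No measurement is at hand that explains why these groups behave alike.

The compounds shown leave open whether a plain phenyl with neither amino nor bromo would stay level with compound 2 and compound 3 or fall back towards compound 1. They also leave open how a methoxy group or a carboxylic acid would read in the place of the bromo.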